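The compounds below may be only part of what the source reports. "The series", "measured", "known", "first", "only" and "open" are said of these compounds alone.

Measured so far in a physicochemical assay for solubility, with a stated time of 4 h, at pH 7.4; on this read-out higher numbers stand for higher solubility and lower numbers for lower solubility
- Compound 1 `CC(=O)CCc1cc(C)c(Oc2cc(Nc3ccc(C#N)cc3)c(N)cc2C(F)(F)F)c(C)c1` gives 0.16 ug/mL
- Compound 2 `Cc1cc(/C=C/C#N)cc(C)c1Oc1cc(Nc2ccc(C#N)cc2)c(N)cc1[N+](=O)[O-]` gives 0.29 ug/mL

Compound 2 lies within the usual scatter of compound 1, so the two values cannot be told apart. Compound 3 `COC(=O)c1cc(N)c(Nc2ccc(C#N)cc2)cc1Oc1c(C)cc(/C=C/C#N)cc1C` is still to be measured. It differs from compound 2 in one place, and that change is methoxycarbonyl in place of nitro on an aromatic carbon with methoxycarbonyl in place of nitro on an aromatic carbon, para to a (4-cyanophenyl)amino group. Among the compounds with values here, no measured pair isolates this change, so the data give no direct size or direction for it. Within the data shown here, the only anchor is compound 2 at 0.29 ug/mL and nothing favours a move either way in this assay for this swap. The expected result is a 1.2-fold lower number from compound 2 to compound 3 (0.06 log units; within the scatter) and no step beyond the scatter. For compound 3 the estimated value is 0.25 ug/mL with an expected range from 0.08 ug/mL to 0.8 ug/mL in this read-out.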

Compound 3, solubility: 1.3 ug/mL
Compound 3: the middle estimate sits 5.2-fold (0.72 log units) below what was measured; measured number outside the range, above it.
By their numbers in this assay, from the lowest: compounds 1 and 2 (each within the scatter of the next); then compound 3.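

Within the data shown here, at the position para to a (4-cyanophenyl)amino group, methoxycarbonyl in place of nitro gives a 4.5-fold higher number from compound 2 to compound 3 (0.65 log units; beyond the scatter) in this assay, the first step beyond the scatter and the first pair to isolate a single change. This position therefore registers on this read-out, even though the leaving and entering groups carry the same counts of hydrogen-bond donors and acceptors. Nothing measured on hand accounts for the step.

This single pair cannot separate a contribution of methoxycarbonyl from the removal of nitro, and a carboxylic acid, a primary amide or a longer ester at this position would help to tell these apart. Among these compounds, also open is whether the swap gives a similar step when the rest of the molecule differs, as only one pair carries it.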